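Amino in place of chloro on the core of compound 1

The source may hold more compounds than are shown below. What is called first, only, known or untested is meant among the compounds shown, and "the series" means these compounds.

Compound 1 `ClCc1cccc(Cn2cnc3c(Cl)nc(Cl)nc32)c1` gives the lower of the two numbers in a functional assay on TK-10 cells (Homo sapiens) for cytotoxicity, read by sulforhodamine B assay, with a stated time of 48 h (a higher number here means a weaker inhibitor of growth, a lower number a stronger inhibitor of growth), at 3980 nM. Compound 2 `ClCc1ccccc1Cn1cnc2ncnc(Cl)c21` gives 9540 nM in this assay, a weaker inhibitor of growth by a margin beyond the scatter. Compound 3 `Nc1nc(Cl)c2ncn(Cc3cccc(CCl)c3)c2n1` is not yet measured; it differs from compound 1 by amino in place of chloro on an aromatic carbon. For the measured compounds named here, no step between measured compounds follows this change, so the two numbers and the scatter are the only guide. The step of a 1.3-fold higher number from compound 1 to compound 3 (0.10 log units; within the scatter) is expected to be small, near the edge of the scatter, toward a weaker inhibitor. Compound 3 is estimated at 5000 nM, within a range from 2000 nM to 13000 nM.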

Compound 3, concentration for total growth inhibition: 7080 nM
Beside the measured number, compound 3's estimate is 1.4-fold (0.15 log units) below it, within the range that was stated.
By their numbers in this assay, from the lowest: compounds 1, 3 and 2 (each within the scatter of the next, the first and the last beyond it).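

In this assay, amino in place of chloro on the aromatic carbon between two ring nitrogen atoms gives a 1.8-fold higher number from compound 1 to compound 3 (0.25 log units; within the scatter) on the shared core. At this position, the exchange adds a hydrogen-bond donor and a hydrogen-bond acceptor, and the read-out stays within the scatter. Nothing available explains the size of this step.

As far as these compounds go, whether a methoxy group or a dimethylamino group on this carbon would also stay within the scatter remains open. From the compounds shown here alone, the effect of amino in place of the remaining chloro group on the core is also open.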